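Ethyl to benzyl: a step away from the limit

A few compounds are considered here, and "the series" means these few. Any claim that something is new, unique, unknown or untested is made for them only; others in the source may bear on it.

In a functional assay on T98G cells (Homo sapiens) for inhibition, read by MTT assay, with a stated time of 72 h (a higher number here means a weaker inhibitor, a lower number a stronger inhibitor), compound 1 `CC(C)NC(=S)NC1CC(C)(C)Oc2ccc(Cl)cc21` gives 91000 nM. Compound 2 `CCNC(=S)NC1CC(C)(C)Oc2ccc(Cl)cc21` gives > 100000 nM, which is a limit and not a number. Within the data shown here, the only measured step, an at least 1.0-fold higher number from compound 1 to compound 2 (0.04 log units; that floor lies within the scatter), lies within the scatter and ends at that limit (the limit of > 100000 nM in this assay, at which 1 of the 2 values shown sits). Compound 3 `CC1(C)CC(NC(=S)NCc2ccccc2)c2cc(Cl)ccc2O1` carries phenyl in place of methyl on a saturated chain carbon bound to an amide-type nitrogen, phenyl in place of methyl on a saturated chain carbon bound to an amide-type nitrogen. Among the measured compounds shown here, with the step of an at least 1.0-fold higher number from compound 1 to compound 2 (0.04 log units; that floor lies within the scatter) as the sole guide, only a modest move towards a lower number is expected, namely an at least 2.2-fold lower number from compound 2 to compound 3 (0.34 log units; beyond the scatter). The estimate for compound 3 is 45000 nM, with an expected range of 15000 nM to 100000 nM.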

Compound 3, half-maximal inhibitory concentration: 99000 nM
Compound 3: middle estimate off by 2.2-fold (0.34 log units), on the low side; low and high end bracket the measured number.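

In this assay, benzyl in place of isopropyl on an amide-type nitrogen gives a 1.1-fold higher number from compound 1 to compound 3 (0.04 log units; within the scatter). A six-membered aromatic ring at this place therefore leaves compound 3 indistinguishable from compound 1, so the larger group opens no route to a lower number here. Phenyl in place of methyl on a saturated chain carbon bound to an amide-type nitrogen gives a number no higher from compound 2 to compound 3 (the limit leaves the size open). That step cannot be read, because compound 2 stands at a limit: the limit of > 100000 nM in this assay, at which 1 of the 3 values shown sits.

Still open, on these data alone, is whether a phenethyl chain or an aminoethyl chain in place of benzyl would give a lower number in this assay.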